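Cytotoxicity notes: from compound 2 to compound 3

The compounds below may be only part of what the source reports. "The series", "measured", "known", "first", "only" and "open" are said of these compounds alone.

Within the data shown here, compound 2 `CCC(O)CNc1nc(N)nc2ccn(Cc3ccccn3)c12` is one of two compounds measured in an ADME assay on HEK293 cells (Homo sapiens) for cytotoxicity, read by ATP content, with a stated time of 6 h; on this read-out lower numbers stand for higher toxicity in this test and higher numbers for lower toxicity in this test. In this assay compound 2 gives only a limit, > 24000 nM. Compound 1 `CCCCNc1nc(N)nc2ccn(CC(=O)NC)c12` likewise gives only a limit in this assay, > 24000 nM. Both values sit at the limit of > 24000 nM in this assay, at which 2 of the 2 values shown sit, so the two compounds show the same thing and no order between them can be read. Compound 3 `Cc1coc(CNc2nc(N)nc3ccn(Cc4ccccn4)c23)n1` has not yet been measured in this assay. It differs from compound 2 in one place: 4-methyl-1,3-oxazol-2-yl in place of 1-hydroxypropyl on a saturated chain carbon bound to a nitrogen on an aromatic ring. Among the measured compounds shown here, no step between measured compounds exists, so nothing here fixes the size of the change. The expected step is a step that the limit leaves unreadable from compound 2 to compound 3, no shift beyond the scatter. Compound 3 is therefore expected to give about 30000 nM in this assay, within 12000 nM to 80000 nM, and most likely to be reported once more as a limit rather than a number.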

Compound 3, half-maximal cytotoxic concentration: > 24000 nM
Compound 3 was reported as a limit (the forecaster's own chance of this, stated with the estimate: 75%); the middle value lies beyond the limit too.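

Among these compounds, compound 2 and compound 3 each give only a limit in this assay and so no step between them can be read: the limit of > 24000 nM in this assay, at which 3 of the 3 values shown sit.

Still open is how far any of the compounds shown lies from that limit, and whether 4-methyl-1,3-oxazol-2-yl in place of 1-hydroxypropyl shifts the half-maximal cytotoxic concentration at all.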